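The compounds below may be only part of what the source reports. "The series", "measured", "known", "first", "only" and "open" are said of these compounds alone.

Measured so far in a functional assay on MDA-MB-435 cells (Homo sapiens) for inhibition; a higher number here means a weaker inhibitor, a lower number a stronger inhibitor:
compound 1 `COc1cc[nH]c1/C=C1/C(=O)Nc2ccc(F)cc21`: > 30000 nM
compound 2 `COc1cc[nH]c1/C=C1\C(=O)Nc2ccc(F)c(C#CC(O)CN)c21`: 130 nM

The entry for compound 1 is a limit of this assay, not a number (the limit of > 30000 nM in this assay, at which 1 of the 2 values shown sits). For the measured compounds named here, compound 2, at 130 nM in this assay, therefore holds the only measured number and is the sole anchor for anything that follows; no step between two measured compounds is available.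

Compound 3 `COc1cc[nH]c1/C=C1\C(=O)Nc2ccc(F)c(C#C[C@H](CO)NCCO)c21` is the next candidate. Relative to compound 2 the change is 2-hydroxy-1-((2-hydroxyethyl)amino)ethyl in place of 2-amino-1-hydroxyethyl on a triple-bonded carbon. With no measured step of comparable kind among the shown compounds, the size of the move cannot be read from the data. The step from compound 2 to compound 3 is expected to be modest, a 1.5-fold higher number from compound 2 to compound 3 (0.19 log units; within the scatter), close to the scatter and with no firm direction. Compound 3 is expected to give about 200 nM in this assay, with a range from 60 nM to 800 nM.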

Compound 3, half-maximal inhibitory concentration: 1270 nM
Compound 3: middle estimate off by 6.4-fold (0.80 log units), on the low side; the whole stated range lies below it.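

In this assay, 2-hydroxy-1-((2-hydroxyethyl)amino)ethyl in place of 2-amino-1-hydroxyethyl on a triple-bonded carbon gives a 9.8-fold higher number from compound 2 to compound 3 (0.99 log units; beyond the scatter). For the compounds shown here, this is the first measured step, and it shows that the group at this place affects potency: the larger of these two groups gives the weaker inhibitor, though compound 3 still returns a measured number rather than a limit. Nothing shown bears on the reason for this step.

Open, going by these compounds, is which part of the exchange carries the step, as the hydroxyethyl on the nitrogen, the altered placement of the hydroxyl and the defined stereocentre all change together. Also open, on these data alone, is how a simple methylamino group, a morpholine ring, a carboxylic acid or a longer chain would read at this place.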